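The source may hold more compounds than are shown below. What is called first, only, known or untested is meant among the compounds shown, and "the series" means these compounds.

Measured so far in the series:

compound 1 `COc1ccc(-c2c[nH]c(=O)n2-c2cc(OC)c(OC)c(OC)c2)cc1OC` — > 50000 nM
compound 2 `COc1ccc(-c2c[nH]c(=O)n2-c2cc(OC)c(OC)c(OC)c2)cc1[N+](=O)[O-]` — > 50000 nM
compound 3 `COc1cc(-n2c(-c3ccc([N+](=O)[O-])cc3)cn(C(C)=O)c2=O)cc(OC)c1OC` — 49600 nM

In a functional assay on K-562R cells (Homo sapiens) for cytotoxicity, read by MTT assay, with a stated time of 48 h (on this read-out lower numbers stand for stronger inhibition and higher numbers for weaker inhibition), compound 1 reaches only a limit of the assay, > 50000 nM. Compound 2 likewise reaches only a limit, > 50000 nM. Among the measured compounds shown here, compound 3 is the one compound with a number, giving 49600 nM in this assay. The change from compound 2 to compound 1 is methoxy in place of nitro on an aromatic carbon, and the step it made is a step that the two limits leave unreadable from compound 2 to compound 1; what is known of it is the limit of > 50000 nM in this assay, at which 2 of the 3 values shown sit.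

Compound 4 `COc1ccc(-c2cn(C(C)=O)c(=O)n2-c2cc(OC)c(OC)c(OC)c2)cc1` is not yet measured. It differs from compound 3 by methoxy in place of nitro on an aromatic carbon, the same kind of change as from compound 2 to compound 1, but here the place is para to a large group, whereas in compound 1 it is ortho to a methoxy group and meta to a large group. How the core of compound 3 differs from that of compound 2 is not broken down here.

Compound 4 is expected to show a step of a 1.0-fold higher number from compound 3 to compound 4 (0.00 log units; within the scatter) in this assay, an expectation resting on compound 3 at 49600 nM and on the earlier step being unreadable. Compound 4 is thus estimated at 50000 nM, between 20000 nM and 120000 nM.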

Compound 4, half-maximal inhibitory concentration: 9500 nM
For compound 4 the middle estimate is 5.3-fold (0.72 log units) above the measured one; the whole stated range lies above it.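

In this assay, replacing nitro with methoxy on an aromatic carbon, para to a large group, gave a 5.2-fold lower number from compound 3 to compound 4 (0.72 log units; beyond the scatter), so on this core the change lowers the number beyond the scatter. This is a single pair, which shows the change acting on one core and gives no rule for carrying it to another, and it does not say why the number fell. On the core shared by compound 1 and compound 2, the step for the same kind of change cannot be read, so whether the drop carries across remains unknown: the limit of > 50000 nM in this assay, at which 2 of the 4 values shown sit.

The compounds shown leave open whether another group in the same place, such as an amine, a carboxylic acid or a longer chain like ethoxy, would give a lower or a higher number than methoxy. They also leave open how much of the result depends on the core of compound 4, since no readable pair separates that core from the change itself.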